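Compound 2 to compound 4 on HeLa cells

A few compounds are considered here, and "the series" means these few. Any claim that something is new, unique, unknown or untested is made for them only; others in the source may bear on it.

Measured so far in a functional assay on HeLa cells (Homo sapiens) for inhibition, read by CCK-8 assay, with a stated time of 48 h; on this read-out lower numbers stand for stronger inhibition and higher numbers for weaker inhibition:
- compound 1 `O=C(NCCNS(=O)(=O)c1ccc(-c2ccccc2Oc2ccc(O)c(O)c2)s1)Nc1cc(Cl)cc(Cl)c1`: > 20000 nM
- compound 2 `COc1cccc(NC(=S)NCCNS(=O)(=O)c2ccc(-c3ccccc3Oc3ccc([N+](=O)[O-])cc3)s2)c1`: > 50000 nM
- compound 3 `O=S(=O)(NCCNC(=S)Nc1ccc(Cl)cc1)c1ccc(-c2ccccc2OCc2ccccc2)s1`: 7000 nM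

Among these, only compound 3 returns a number, and in this assay compound 3 gives 7000 nM. For compound 1 the read-out is a limit of the assay, (the limit of > 20000 nM in this assay, at which 1 of the 3 values shown sits), and not a number. Going by these compounds, compound 2 stands no better: its read-out is also a limit, (the limit of > 50000 nM in this assay, at which 1 of the 3 values shown sits), so its true potency is unknown apart from lying at or beyond that mark. Of the two compounds that differ from compound 2 in several places at once, only what their values show can be said: compound 3 was measured while compound 1 and compound 2 were not.

The unmeasured compound 4 `COc1ccc(NC(=O)NCCNS(=O)(=O)c2ccc(-c3ccccc3Oc3ccc([N+](=O)[O-])cc3)s2)cc1` departs from compound 2 by a single exchange: a group of 11 heavy atoms (8 carbon, 1 nitrogen, 2 oxygen; one six-membered aromatic ring of carbon only) in place of a group of 11 heavy atoms (8 carbon, 1 nitrogen, 1 oxygen, 1 sulfur; one six-membered aromatic ring of carbon only), on an amine nitrogen. The change replaces a thiocarbamoyl-bearing methoxyphenyl with a (4-methoxyphenyl)carbamoyl on the amine nitrogen attached to the saturated chain carbon. Among the compounds with values here, no measured step of this kind exists in the set, so the expectation rests on compound 2 itself. The step from compound 2 to compound 4 is expected to be a number no higher from compound 2 to compound 4 (the limit leaves the size open), that is, no change beyond the scatter. Compound 4 is therefore expected to give about 50000 nM in this assay, within 15000 nM to 200000 nM.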

Compound 4, half-maximal inhibitory concentration: > 20000 nM
Compound 4: no number, only a limit; the forecaster's own chance of this, stated with the estimate: 70%; the middle value does not contradict the limit.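

In this assay compound 4 gives > 20000 nM, which is a limit and not a number. Compound 2 gives > 50000 nM, also a limit. Within the data shown here, no step from compound 2 to compound 4 can therefore be read. The compounds shown leave open whether the (4-methoxyphenyl)carbamoyl on the amine nitrogen shifts potency at all.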